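Extending the ester chain of compound 1

The compounds below may be only part of what the source reports. "The series", "measured", "known", "first", "only" and "open" are said of these compounds alone.

Compound 1 `CCCCCCC(=O)O[C@H](CC=C(C)C)C1=CC(=O)c2c(O)ccc(O)c2C1=O` is the weaker of the two measured esters of the shared core: in an assay on HeLa cells for inhibition of DNA topoisomerase 1 (Homo sapiens) (a higher number here means a weaker inhibitor, a lower number a stronger inhibitor), compound 1 gives 625000 nM, the highest of the two numbers, while compound 2 `CC(C)=CC[C@@H](OC(=O)C=C(C)C)C1=CC(=O)c2c(O)ccc(O)c2C1=O` gives 77000 nM. For the measured compounds named here, the one measured step, an 8.1-fold lower number from compound 1 to compound 2 (0.91 log units; beyond the scatter), replaces the hexyl group on the carbonyl carbon by 2-methylprop-1-en-1-yl. Compound 3 `CCCCCCCC/C=C/CCCCCCCC(=O)O[C@H](CC=C(C)C)C1=CC(=O)c2c(O)ccc(O)c2C1=O` keeps the hexyl ester of compound 1 and adds to it: a group of 11 heavy atoms (11 carbon; no ring) in place of a hydrogen atom, on a saturated chain carbon, six bonds along the chain from a carbonyl carbon. Going by the values given here, no measured step lengthens a chain in this way; the step from compound 1 to compound 2 changes the acyl group entirely and so bears on it only loosely. With nothing pointing in either direction, the expected step of a 1.1-fold higher number from compound 1 to compound 3 (0.05 log units; within the scatter) is none beyond the scatter. Compound 3 is therefore estimated at 700000 nM in this assay, within a range of 250000 nM to 2000000 nM.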

Compound 3, half-maximal inhibitory concentration: > 625000 nM
Compound 3: a limit, no number; the forecaster's own chance of this, stated with the estimate: 30%; the middle value lies beyond the limit too.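

In this assay compound 3 gives > 625000 nM as a limit and not a number. The step is a number no lower from compound 1 to compound 3 (the limit leaves the size open) and so adds what the change of acyl group could not show: lengthening the hexyl ester itself, with a group of 11 heavy atoms (11 carbon; no ring) on a saturated chain carbon, six bonds along the chain from a carbonyl carbon, gave no lower number. How far the number rose, if it rose at all, cannot be read, and the result rests on a limit: the limit of > 625000 nM in this assay, at which 1 of the 3 values shown sits.

The compounds shown leave open what an ester chain of intermediate length, such as octyl, would give in this assay as well as an acyl chain carrying an amine or a carboxylic acid. They also leave open whether another short branched acyl group, such as isopropyl on the carbonyl carbon, would match compound 2.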